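Removing the carbamate cap: what happens to stability

This account rests on a few compounds, and the source may have more. Where it says the series, first, only, none or still open, it means among the compounds named here.

Measured compounds in an ADME assay on microsomes from liver (Rattus norvegicus) for metabolic stability, with a stated time of 10 min; on this read-out higher numbers stand for a more stable compound and lower numbers for a less stable compound:
- compound 1 `CC(C)OC(=O)NCCS(=O)(=O)NC(=O)c1ccc(Nc2nc(NC3(c4ccc(Cl)cc4)CC3)nc(OCC(F)(F)F)n2)cc1`: 73%
- compound 2 `CNC(=O)NCCS(=O)(=O)NC(=O)c1ccc(Nc2nc(NC3(c4ccc(Cl)cc4)CC3)nc(OCC(F)(F)F)n2)cc1`: 100%
- compound 3 `COC(=O)NCCS(=O)(=O)NC(=O)c1ccc(Nc2nc(NC3(c4ccc(Cl)cc4)CC3)nc(OCC(F)(F)F)n2)cc1`: 100%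

Compound 1 stands lowest of the three numbers. Its nearest neighbour is compound 2, reached by the step of a number 27 percentage points higher from compound 1 to compound 2 (beyond the scatter), and compound 3 sits at the same distance through a number 27 percentage points higher from compound 1 to compound 3 (beyond the scatter). Between compound 2 and compound 3 there is no change at the digits printed from compound 2 to compound 3 (within the scatter), so those two cannot be told apart.

Compound 4 `NCCS(=O)(=O)NC(=O)c1ccc(Nc2nc(NC3(c4ccc(Cl)cc4)CC3)nc(OCC(F)(F)F)n2)cc1` is not yet measured. Compared with compound 1 it shows the change (hydrogen in place of isopropoxycarbonyl on an amine nitrogen). Both steps that have been measured from compound 1 touch the same isopropoxycarbonyl group, once by exchanging the isopropoxy part, once by exchanging the isopropyl part, and both raised stability by a modest amount. The step to compound 4 removes the whole group, leaving a bare amine on the chain. On this basis the expected direction for compound 4 in this assay is upward, by roughly the same modest size as the two known steps, giving an expected a number 19 percentage points higher from compound 1 to compound 4 (beyond the scatter). The estimate for compound 4 is therefore 92%, expected to fall between 72% and 100%.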

Compound 4, percent of the compound remaining: 100%
Compound 4: the middle estimate sits 8 percentage points below what was measured; the measured number falls inside the stated range.
By their numbers in this assay, from the lowest: compound 1; then compounds 2, 3 and 4 (each within the scatter of the next).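

In this assay the amine nitrogen on the chain turns out to need no cap at all: replacing the whole isopropoxycarbonyl group, with its six heavy atoms, by a single hydrogen gives a number 27 percentage points higher from compound 1 to compound 4 (beyond the scatter), a step of the same printed size as the two smaller edits. The bare 2-aminoethyl chain also cannot be told apart from the capped chains, with no change at the digits printed from compound 3 to compound 4 (within the scatter) for the methoxycarbonyl cap and no change at the digits printed from compound 2 to compound 4 (within the scatter) for the methylcarbamoyl cap. Among these four compounds only the isopropoxycarbonyl compound stands apart, and nothing measured here accounts for that.

Compounds 2, 3 and 4 share one printed value, so this read-out leaves any order among them open. As far as these compounds go, it also stays open where stability starts to fall between the methoxycarbonyl and isopropoxycarbonyl caps, as an ethoxycarbonyl or a tert-butoxycarbonyl group on the same nitrogen could show, and whether an acetyl cap or a longer chain carrying the amine would behave like the bare 2-aminoethyl chain.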